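The compounds below may be only part of what the source reports. "The series", "measured", "known", "first", "only" and "open" are said of these compounds alone.

Measured compounds in a functional assay on HCT-116 cells (Homo sapiens) for antiproliferative activity, read by MTT assay, with a stated time of 72 h; a lower number here means a stronger inhibitor of growth, a higher number a weaker inhibitor of growth:
Compound 1, `Clc1ccc(Nc2nc3ncccc3n2Cc2ccccc2)cc1`, gives 59500 nM.
Compound 2, `Cn1nc(-c2ccnc(Nc3ccc(O)cc3)n2)c2ccccc21`, gives 8430 nM.
Compound 3, `Cc1ccc(Nc2nccc(-c3nn(C)c4ccccc34)n2)cc1`, gives 8640 nM.

Compound 3 has the second highest of the three numbers. Among the compounds with values here, compound 2 sits closest to it, and the only single-point step among the measured compounds, a 1.0-fold higher number from compound 2 to compound 3 (0.01 log units; within the scatter), is within the scatter. Within the data shown here, compound 1, built on a different core, gives a higher number than compound 3, a gap beyond the scatter, but it shares no single-point step with compound 3 and is set aside here.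

Compound 4, `Cn1nc(-c2ccnc(Nc3cccc(Cl)c3)n2)c2ccccc21`, keeps the shared core of compound 2 and compound 3 and differs from compound 3 by 3-chlorophenyl in place of 4-methylphenyl on a nitrogen on an aromatic ring. Among the measured compounds shown here, the one step that bears on this position, from compound 2 to compound 3, changed the group on that phenyl ring without moving the number beyond the scatter. Nothing measured speaks to a chlorine on the ring or to the changed placement, so the expectation is no step beyond the scatter, a 1.1-fold lower number from compound 3 to compound 4 (0.03 log units; within the scatter). Compound 4 is therefore expected to give about 8000 nM in this assay, in a range from 3000 nM to 25000 nM.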

Compound 4, concentration for 50% growth inhibition: 6400 nM
Beside the measured number, compound 4's estimate is 1.3-fold (0.10 log units) above it, within the range that was stated.
By their numbers in this assay, from the lowest: compounds 4, 2 and 3 (each within the scatter of the next); then compound 1.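

In this assay, the change from 4-methylphenyl to 3-chlorophenyl on a nitrogen on an aromatic ring gives a 1.4-fold lower number from compound 3 to compound 4 (0.13 log units; within the scatter), and the change from 4-hydroxyphenyl to 3-chlorophenyl gives a 1.3-fold lower number from compound 2 to compound 4 (0.12 log units; within the scatter). Within the data shown here, this position has now taken a chlorine-bearing phenyl group, with its substituent at a different place on the ring, and no step among the three compounds with the shared core lies beyond the scatter. Nothing available explains this result.

The chlorine and its changed placement arrive together in compound 4, so their separate contributions cannot be told apart. As far as these compounds go, it remains open whether an amine, a carboxylic acid or a longer chain on this phenyl ring would give a step beyond the scatter.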